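Swapping the Ring on the Sulfonyl Sulfur

The source may hold more compounds than are shown below. What is called first, only, known or untested is meant among the compounds shown, and "the series" means these compounds.

Three compounds sharing one core differ only in the ring attached to a sulfonyl sulfur. In an ADME assay on cells (Hepatocyte, Rattus norvegicus) for metabolic stability (a higher number here means faster removal of the compound, a lower number slower removal), compound 1 `Cc1ccc2[nH]c(C(=O)N[C@H]3CN(S(=O)(=O)c4ccccc4)C[C@@H]3C(=O)NCCN(C)C)cc2c1` gives 16 uL/min, compound 2 `Cc1ccc2[nH]c(C(=O)N[C@H]3CN(S(=O)(=O)c4ccnnc4)C[C@@H]3C(=O)NCCN(C)C)cc2c1` gives 2 uL/min, and compound 3 `Cc1ccc2[nH]c(C(=O)N[C@H]3CN(S(=O)(=O)c4ccnc(C)c4)C[C@@H]3C(=O)NCCN(C)C)cc2c1` gives 8 uL/min. Compound 2 has the lowest number of the three, as shown by an 8.0-fold lower number from compound 1 to compound 2 (0.90 log units; beyond the scatter) and a 4.0-fold higher number from compound 2 to compound 3 (0.60 log units; beyond the scatter). Compound 4 `Cc1ccc2[nH]c(C(=O)N[C@H]3CN(S(=O)(=O)c4cn(C)nc4C)C[C@@H]3C(=O)NCCN(C)C)cc2c1` carries the change (1,3-dimethyl-1H-pyrazol-4-yl in place of pyridazin-4-yl on a sulfonyl sulfur). Both measured steps that replace the pyridazin-4-yl ring gave a higher number in this assay, so a modest rise beyond the scatter is expected here too, though the new ring has not been tested. The expected step is a 3.0-fold higher number from compound 2 to compound 4 (0.48 log units; beyond the scatter). Compound 4 is therefore estimated at 6 uL/min, with a range from 2 uL/min to 16 uL/min.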

Compound 4, intrinsic clearance in a liver preparation (reported as CLH), per the amount of preparation that the assay uses: 4 uL/min
Estimate against measurement, compound 4: 1.5-fold (0.18 log units) above; the measured number falls inside the stated range.
By their numbers in this assay, from the lowest: compounds 2, 4, 3 and 1 (each within the scatter of the next, the first and the last beyond it).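

The 1,3-dimethyl-1H-pyrazol-4-yl ring shows that a five-membered ring on the sulfonyl sulfur can also give a lower number than phenyl in this assay, with a 4.0-fold lower number from compound 1 to compound 4 (0.60 log units; beyond the scatter). It cannot be separated from either nitrogen-containing six-membered ring, with a 2.0-fold higher number from compound 2 to compound 4 (0.30 log units; within the scatter) and a 2.0-fold lower number from compound 3 to compound 4 (0.30 log units; within the scatter), even though those two rings stand apart from each other.

No available evidence explains these differences. Also open, as far as these compounds go, is how a five-membered ring carrying an amine or a carboxylic acid instead of the two methyl groups would behave in this assay.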